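The source may report more compounds than this note shows. Statements on the series, on what has been measured and on what is new or still open speak of the compounds shown alone.

Working notes on a small boronic-acid series tested in an ADME assay on L929 cells (Mus musculus) for cytotoxicity, read by resazurin assay, with a stated time of 72 h; on this read-out higher numbers stand for weaker inhibition and lower numbers for stronger inhibition.

Compound 1 `O=C(NC1CCCCC1)c1cccn1-c1ccc2c(c1)B(O)OC2` carries an amide on the shared core. In this assay compound 1 gives > 10 ug/mL, which is a limit of the assay and not a number. Compound 2 `CC(=O)c1ccn(-c2ccc3c(c2)B(O)OC3)c1` carries an acetyl group on the same core. In this assay compound 2 gives > 10 ug/mL, again a limit rather than a number. Going by the values given here, compound 2 therefore stands only at a limit, and the one further value shown is a limit as well: the limit of > 10 ug/mL in this assay, at which 2 of the 2 values shown sit. Among the compounds with values here, no step between measured compounds is available, so no measured size of change can be quoted.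

Compound 3 `Cc1cccc(C(=O)c2ccn(-c3ccc4c(c3)B(O)OC4)c2)c1` is the next member. It differs from compound 2 in one place: 3-methylphenyl in place of methyl on a carbonyl carbon. With both measured values sitting at the limit, no direction is indicated by the data. The step from compound 2 to compound 3 is expected to be a step that the limit leaves unreadable from compound 2 to compound 3, none beyond the scatter. Compound 3 is accordingly estimated at 15 ug/mL, with a range from 5 ug/mL to 40 ug/mL, and most likely reported only as a limit once more.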

Compound 3, half-maximal inhibitory concentration: > 10 ug/mL
Compound 3 ended at the assay's limit; the forecaster's own chance of this, stated with the estimate: 70%; the middle value lies beyond the limit too.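

No step can be read between compound 2 and compound 3, since the values of both are limits of the assay and not numbers: the limit of > 10 ug/mL in this assay, at which 3 of the 3 values shown sit.

The compounds shown leave open where any of them would fall as a number in this assay and whether the groups on the shared core differ at all on this read-out.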